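Putting a Chlorophenyl Back in Place

The source may hold more compounds than are shown below. What is called first, only, known or untested is meant among the compounds shown, and "the series" means these compounds.

Among the compounds with values here, in a functional assay on MCF7 cells (Homo sapiens) for cytotoxicity, read by MTT assay, with a stated time of 48 h (a higher number here means a weaker inhibitor, a lower number a stronger inhibitor), compound 1 (`O=C1/C(=C\c2ccc(Cl)cc2)S/C(=N/c2ccccc2)N1Cc1ccncc1`) gives 54900 nM as its reading, while compound 2 (`CCOc1cc(/C=C2/S/C(=N/c3ccccc3)N(Cc3ccncc3)C2=O)ccc1O`) gives 20100 nM and so holds the lower of the two numbers measured so far. Compound 3 (`O=C1/C(=C\c2cccc(Cl)c2)S/C(=N/c2ccccc2)N1Cc1ccncc1`) keeps the shared core but has 3-chlorophenyl in place of 3-ethoxy-4-hydroxyphenyl on a double-bonded chain carbon bound to a double-bonded ring carbon. Within the data shown here, this largely reverses the one measured change, since compound 1 also carries a chlorophenyl group, though as 4-chlorophenyl rather than 3-chlorophenyl. Among the measured compounds shown here, no measurement yet shows how much that difference matters. For the measured compounds named here, the only guide is a 2.7-fold lower number from compound 1 to compound 2 (0.44 log units; beyond the scatter) as seen with 3-ethoxy-4-hydroxyphenyl in place of 4-chlorophenyl, a modest step. A step of similar size in the opposite direction, toward a higher number and a weaker inhibitor, is therefore expected in this assay for this change. The estimated step is a 2.2-fold higher number from compound 2 to compound 3 (0.35 log units; beyond the scatter) with wide uncertainty. For compound 3 the expected value is 45000 nM within an estimated range from 20000 nM to 100000 nM for now.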

Compound 3, half-maximal inhibitory concentration: 29800 nM
Compound 3: middle estimate off by 1.5-fold (0.18 log units), on the high side; the range from low to high includes it.
By their numbers in this assay, from the lowest: compounds 2, 3 and 1 (each within the scatter of the next, the first and the last beyond it).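

Read in this assay, putting 3-chlorophenyl in place of 3-ethoxy-4-hydroxyphenyl gives a 1.5-fold higher number from compound 2 to compound 3 (0.17 log units; within the scatter) and so stays within the scatter: at this place, a group with 0 hydrogen-bond donors and 0 hydrogen-bond acceptors gives a reading that cannot be told apart from that of compound 2. Putting 3-chlorophenyl in place of 4-chlorophenyl gives a 1.8-fold lower number from compound 1 to compound 3 (0.27 log units; within the scatter) and also stays within the scatter, so compound 3 cannot be separated from either neighbour, even though compound 1 and compound 2 differ beyond the scatter, and the step between those two no longer reads as a simple contrast between a chlorophenyl and 3-ethoxy-4-hydroxyphenyl. Nothing available here offers a reason for these readings.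

As far as these compounds go, whether the lower number of compound 2 against compound 1 depends on the ethoxy group, the hydroxy group or the two together remains open. Also open, from the compounds shown here alone, is how this place would respond to a phenyl ring carrying an amine or a carboxylic acid, or to a longer chain in place of the ethoxy group.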